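Swapping an aromatic tail for cyclohexyl

This account rests on a few compounds, and the source may have more. Where it says the series, first, only, none or still open, it means among the compounds named here.

Within the data shown here, in a functional assay on RAW264.7 cells (Mus musculus) for inhibition, read by Griess assay, with stated times of 1 h and 24 h (on this read-out higher numbers stand for weaker inhibition and lower numbers for stronger inhibition), compound 3 `COc1cc(OC)c2c(c1)C(C(O)c1ccc(OCc3ccc(OC(F)(F)F)cc3)cc1)OC2=O` gives 8140 nM, the higher of the two actual numbers so far. The other number belongs to compound 2 `C=CCCOc1ccc(C(O)C2OC(=O)c3c(OC)cc(OC)cc32)cc1`, at 1330 nM. Compound 1 `CCOCCOc1ccc(C(O)C2OC(=O)c3c(OC)cc(OC)cc32)cc1` gives only a limit, > 10000 nM, not a number.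

Compound 4 `COc1cc(OC)c2c(c1)C(C(O)c1ccc(OCC3CCCCC3)cc1)OC2=O` has cyclohexyl in place of 4-(trifluoromethoxy)phenyl on a saturated chain carbon bound to an oxygen on an aromatic ring. Two measured steps, both beyond the scatter, show that this part of the molecule counts: a 6.1-fold higher number from compound 2 to compound 3 (0.79 log units; beyond the scatter) and an at least 7.5-fold lower number from compound 1 to compound 2 (0.87 log units; beyond the scatter). Cyclohexyl, like the allyl of compound 2 at 1330 nM, holds only carbon, so a partial move towards that number is expected. The expected change is a 2.3-fold lower number from compound 3 to compound 4 (0.37 log units; beyond the scatter), towards stronger inhibition. For compound 4 the estimated value is 3500 nM, within a range of 1200 nM to 10000 nM.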

Compound 4, half-maximal inhibitory concentration: > 10000 nM
Compound 4 ended at the assay's limit; the forecaster's own chance of this, stated with the estimate: 15%; at least 2.8-fold (0.45 log units) between middle value and limit.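

Holding only carbon is not enough at this place: with cyclohexyl in place of allyl there is an at least 7.5-fold higher number from compound 2 to compound 4 (0.87 log units; beyond the scatter). As far as these compounds go, replacing 4-(trifluoromethoxy)phenyl with cyclohexyl gives an at least 1.2-fold higher number from compound 3 to compound 4 (0.08 log units; that floor lies within the scatter), so this swap shows no stronger inhibition, and its true size stays unknown. Compound 4 gives a limit, not a number, and the step between the two limits cannot be read: the limit of > 10000 nM in this assay, at which 2 of the 4 values shown sit.

From the compounds shown here alone, it remains open whether the double bond of the allyl group matters, which a saturated propyl group would test. Going by these compounds, how an amine or a carboxylic acid at the end of the chain would behave also remains open.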